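The source may hold more compounds than are shown below. What is called first, only, known or untested is meant among the compounds shown, and "the series" means these compounds.

Measured so far in an ADME assay on HepG2 cells (Homo sapiens) for cytotoxicity, read by CellTiter-Glo and ATP content, with a stated time of 72 h; a lower number here means that less compound is needed, a higher number that more compound is needed for the effect:

Compound 1, `CN(Cc1cccc(F)c1)C(=O)CNC(=O)c1ccc(S(C)(=O)=O)c([N+](=O)[O-])c1`; in this assay compound 1 gives > 27000 nM, which is a limit of the assay and not a number.
Compound 2, `CS(=O)(=O)c1ccc(C(=O)N2CCC(C(=O)N3CCc4ccccc4C3)CC2)cc1[N+](=O)[O-]`; compound 2 gives > 27000 nM, again a limit.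
Compound 3, `CN(CC(=O)N(Cc1ccccc1)Cc1ccccc1)C(=O)c1ccc(S(C)(=O)=O)c([N+](=O)[O-])c1`; compound 3 gives > 27000 nM, also a limit.

Compound 2 therefore stands at the limit of > 27000 nM in this assay, at which 3 of the 3 values shown sit. Nothing in these numbers sets compound 2 apart from compound 1 or compound 3, as each of them shows only the same limit. Among the measured compounds shown here, no step between measured compounds is known, so no measured step anchors the next change.

The unmeasured compound 4, `CN(Cc1ccccc1)C(=O)C1CCN(C(=O)c2ccc(S(C)(=O)=O)c([N+](=O)[O-])c2)CC1`, differs from compound 2 as follows: benzyl(methyl)amino in place of 1,2,3,4-tetrahydroisoquinolin-2-yl on a carbonyl carbon. As compound 1, compound 2 and compound 3 all sit at the limit of > 27000 nM in this assay, at which 3 of the 3 values shown sit, the step is expected to be none beyond the scatter, and the estimated step that the limit leaves unreadable from compound 2 to compound 4 is set accordingly. Compound 4 is expected to give about 40000 nM in this assay, in the range 20000 nM to 120000 nM, most likely reported again only as a limit.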

Compound 4, half-maximal effective concentration: > 27000 nM
Compound 4: no number, only a limit; the forecaster's own chance of this, stated with the estimate: 85%; the middle value does not contradict the limit.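

No step can be read from compound 2 to compound 4 in this assay, since each shows only a limit of the assay: the limit of > 27000 nM in this assay, at which 4 of the 4 values shown sit.

The compounds shown leave open at what concentration any of them reaches the half-maximal effect, and whether benzyl(methyl)amino in place of 1,2,3,4-tetrahydroisoquinolin-2-yl changes it.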